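The source may hold more compounds than are shown below. What is called first, only, known or untested is meant among the compounds shown, and "the series" means these compounds.

Three compounds of one series have been measured in an ADME assay on cells (Mus musculus, strain BALB/C) for cytotoxicity, read by MTT assay, with a stated time of 24 h; on this read-out lower numbers stand for higher toxicity in this test and higher numbers for lower toxicity in this test:

compound 1, `Cc1ccc(C(=O)N/N=C/c2ccccc2F)c(O)c1`, gives 362000 nM
compound 2, `Cc1ccc(C(=O)N/N=C/c2ccccc2[N+](=O)[O-])c(O)c1`, gives 644000 nM
compound 3, `Cc1ccc(C(=O)N/N=C/c2ccc(F)cc2)c(O)c1`, gives 568000 nM

Compound 2 differs from compound 1 by nitro in place of fluoro on an aromatic carbon, and that change gave a 1.8-fold higher number from compound 1 to compound 2 (0.25 log units; within the scatter). Compound 3 is built from the same atoms as compound 1, joined differently; the difference between the two cores is not broken down here. The number for compound 3 in this assay lies within the usual scatter of the numbers for compound 1 and compound 2, so no order among the three can be drawn.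

Compound 4, `Cc1ccc(C(=O)N/N=C/c2ccc([N+](=O)[O-])cc2)c(O)c1`, has not yet been measured. It differs from compound 3 by nitro in place of fluoro on an aromatic carbon. This is the same kind of change as that from compound 1 to compound 2, though not the same: in compound 2 the nitro sits ortho to a large group, in compound 4 para to a large group. Within the data shown here, the only prior instance of this kind of change produced a 1.8-fold higher number from compound 1 to compound 2 (0.25 log units; within the scatter), and nothing among the three measured compounds points to a different outcome. In this assay a step of a 1.6-fold higher number from compound 3 to compound 4 (0.20 log units; within the scatter) is therefore expected, of about the same size as the earlier one. Compound 4 is accordingly estimated at 900000 nM, with a plausible range from 400000 nM to 2000000 nM.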

Compound 4, half-maximal cytotoxic concentration: 734000 nM
Estimate against measurement, compound 4: 1.2-fold (0.09 log units) above; low and high end bracket the measured number.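

In this assay, nitro in place of fluoro on an aromatic carbon gave a 1.3-fold higher number from compound 3 to compound 4 (0.11 log units; within the scatter), and the two cores do not differ in their response to this change: the same change on two cores in this assay, a 1.8-fold higher number (0.25 log units; within the scatter) from compound 1 to compound 2 and a 1.3-fold higher number (0.11 log units; within the scatter) from compound 3 to compound 4, 1.4-fold (0.14 log units) apart, within the scatter of two such steps

Neither step stands clear of the scatter, so what carries from one core to the other is the absence of a readable effect, not a dependable shift in the number. Among these compounds, the comparison rests on only two pairs and does not show how the same change would behave on any other core.

The compounds shown leave open how an amine, a carboxylic acid or a longer chain in place of fluoro or nitro would compare in this assay. Whether any such group would give a step beyond the scatter also remains open, as both steps shown stay within it.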